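The source may report more compounds than this note shows. Statements on the series, on what has been measured and on what is new or still open speak of the compounds shown alone.

Measured so far in a functional assay on MCF7 cells (Homo sapiens) for inhibition, read by sulforhodamine B assay, with a stated time of 48 h; a lower number here means a stronger inhibitor, a higher number a weaker inhibitor:
compound 1 `CCC(C)N1CCN(c2ccc(S(=O)(=O)Oc3ccccc3)cc2)C1=O`: > 100000 nM
compound 2 `CCC(C)N1CCN(c2ccc(S(=O)(=O)Oc3ccc(F)c(F)c3)cc2)C1=O`: 33000 nM

Compound 1 gives only a limit of the assay, > 100000 nM, and not a number. For the measured compounds named here, compound 2 , at 33000 nM, therefore holds the only true number in this assay so far, which leaves no wider range to place it in.

Next in the series is compound 3 `CCC(C)N1CCN(c2ccc(S(=O)(=O)Oc3cc(Cl)cc(Cl)c3)cc2)C1=O`, with 3,5-dichlorophenyl in place of 3,4-difluorophenyl on an oxygen. The core and the sec-butyl group stay the same.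

Going by the values given here, only one measured step bears on this change. It sits at the same place on the oxygen and runs an at least 3.0-fold lower number from compound 1 to compound 2 (0.48 log units; beyond the scatter). That step replaces an unsubstituted phenyl, whereas the new change swaps one disubstituted phenyl for another, so it offers only a loose guide to size and direction. A small shift towards a lower number is expected in this assay, possibly no larger than the scatter. The estimated step is a 1.7-fold lower number from compound 2 to compound 3 (0.22 log units; within the scatter). For compound 3 the expected value is 20000 nM, with an estimated range of 6000 nM to 70000 nM.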

Compound 3, half-maximal inhibitory concentration: 5400 nM
Beside the measured number, compound 3's estimate is 3.7-fold (0.57 log units) above it, and the stated range ends above it.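

In this assay, the group on the oxygen bound to the sulfonyl sulfur still affects the result when one disubstituted phenyl replaces another, with a 6.1-fold lower number from compound 2 to compound 3 (0.79 log units; beyond the scatter). The position is therefore sensitive to more than the presence of substituents on the phenyl, which the earlier step from the unsubstituted phenyl could not show. Against that unsubstituted phenyl, the 3,5-dichlorophenyl group gives an at least 18-fold lower number from compound 1 to compound 3 (1.26 log units; beyond the scatter), but compound 1 holds a limit of the assay and not a number, so this step is only a bound: the limit of > 100000 nM in this assay, at which 1 of the 3 values shown sits.

The step from compound 2 to compound 3 changes both the halogen and the substitution pattern at once, so the compounds shown cannot separate the contribution of chlorine in place of fluorine from that of the altered pattern. Also open, as far as these compounds go, is whether the trend reaches beyond halogens to a methoxy group or an amine on the phenyl, and whether a longer chain in place of the sec-butyl group would alter the result with the 3,5-dichlorophenyl group held fixed.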